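The source may report more compounds than this note shows. Statements on the series, on what has been measured and on what is new or still open speak of the compounds shown alone.

Compound 1 `C=CCOc1ccc2c(=O)c(-c3ccc(O)cc3)coc2c1` carries an allyl group on an oxygen of its core. Among the measured compounds shown here, in an assay (Cricetulus griseus) for inhibition of aldehyde dehydrogenase, mitochondrial (Homo sapiens) (on this read-out lower numbers stand for stronger inhibition and higher numbers for weaker inhibition), compound 1 gives 180 nM, the highest of the two numbers measured so far; compound 2 `CC(C)Oc1ccc2c(=O)c(-c3ccc(O)cc3)coc2c1` gives 80 nM, and the change a 2.3-fold lower number from compound 1 to compound 2 (0.35 log units; beyond the scatter) is a modest improvement. Compound 3 `CCOC(=O)CCCCCOc1ccc2c(=O)c(-c3ccc(O)cc3)coc2c1` differs from compound 1 by 4-(ethoxycarbonyl)butyl in place of vinyl on a saturated chain carbon bound to an oxygen on an aromatic ring. Only the allyl-to-isopropyl step offers any guidance, and it concerns a different kind of change, so little can be inferred. For compound 3 a small shift, a 1.4-fold higher number from compound 1 to compound 3 (0.14 log units; within the scatter), toward weaker inhibition is expected. Compound 3 is therefore estimated at 250 nM, within 80 nM to 800 nM.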

Compound 3, half-maximal inhibitory concentration: 280 nM
For compound 3 the middle estimate is 1.1-fold (0.05 log units) below the measured one, within the range that was stated.
By their numbers in this assay, from the lowest: compound 2; then compounds 1 and 3 (each within the scatter of the next).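

In this assay, putting 4-(ethoxycarbonyl)butyl in place of vinyl gives a 1.6-fold higher number from compound 1 to compound 3 (0.19 log units; within the scatter) and so compounds 1 and 3 cannot be told apart. The earlier compounds shown here carried only short groups on this oxygen, whereas this result shows that a far longer chain ending in an ethyl ester can sit here and inhibition stays in the same range. Nothing available here accounts for this result. Open, as far as these compounds go, is what a carboxylic acid in place of the ethyl ester would give, or an amine at the chain end. A chain of intermediate length also remains to be placed.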